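A Second Chloro Group on Two Related Cores

This account rests on a few compounds, and the source may have more. Where it says the series, first, only, none or still open, it means among the compounds named here.

Measured so far in a functional assay on U-251 cells (Homo sapiens) for cytotoxicity, read by sulforhodamine B assay, with a stated time of 48 h; on this read-out higher numbers stand for lower toxicity in this test and lower numbers for higher toxicity in this test:
compound 1 `ClCc1cccc(Cn2cnc3ncnc(Cl)c32)c1` gives > 100000 nM
compound 2 `ClCc1cccc(Cn2cnc3c(Cl)ncnc32)c1` gives 6760 nM
compound 3 `ClCc1cccc(Cn2cnc3c(Cl)nc(Cl)nc32)c1` gives 5620 nM

Of the compounds shown here, three have been measured in this assay. For compound 1 the reading is only a limit of the assay, not a number, and it sits at the limit of > 100000 nM in this assay, at which 1 of the 3 values shown sits. Compound 2 gives a number, and compound 3 gives one as well; the step of a 1.2-fold lower number from compound 2 to compound 3 (0.08 log units; within the scatter) is chloro in place of hydrogen on an aromatic carbon. Compound 1 and compound 2 share the same atoms joined differently; the difference between the two cores is not broken down here.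

Compound 4 `ClCc1cccc(Cn2cnc3nc(Cl)nc(Cl)c32)c1` has not yet been measured in this assay. Among the measured compounds shown here, it differs from compound 1 by chloro in place of hydrogen on an aromatic carbon, which is the same change, at the same kind of place, as the one from compound 2 to compound 3. Because that earlier step was a 1.2-fold lower number from compound 2 to compound 3 (0.08 log units; within the scatter), compound 4 is expected to remain close to compound 1, and most likely to come back again as a limit rather than a number. The estimate for compound 4 in this assay is 100000 nM, with a range from 15000 nM to 400000 nM, meaning an expected step of a number no higher from compound 1 to compound 4 (the limit leaves the size open).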

Compound 4, concentration lethal to 50% of the cells: 5120 nM
For compound 4 the middle estimate is 20-fold (1.29 log units) above the measured one; the whole stated range lies above it.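

In this assay, chloro in place of hydrogen on an aromatic carbon, between two ring nitrogen atoms on the core of compound 1, gave an at least 19-fold lower number from compound 1 to compound 4 (1.29 log units; beyond the scatter). The same change did not carry over from one core to the other with the same size: the same change on two cores in this assay, a 1.2-fold lower number (0.08 log units; within the scatter) from compound 2 to compound 3 and an at least 19-fold lower number (1.29 log units; beyond the scatter) from compound 1 to compound 4, at least 16-fold (1.21 log units) apart, beyond the scatter of two such steps. Among the compounds shown here, compound 1 gives > 100000 nM, which is a limit of the assay and not a number, and with only one pair on each core the result does not show why the two cores differ, nor how large the step on the core of compound 1 truly is.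

The compounds shown leave open whether an amine or a methoxy group in that same place would also differ between the two cores as chloro does. They also leave open whether the readings on either core would hold with a hydroxymethyl group in place of the chloromethyl group.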